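Swapping the aryl group on a four-membered ring

A few compounds are considered here, and "the series" means these few. Any claim that something is new, unique, unknown or untested is made for them only; others in the source may bear on it.

Measured in a functional assay on MCF7 cells (Homo sapiens) for antiproliferative activity, read by MTT assay, with stated times of 24 h and 72 h; on this read-out higher numbers stand for weaker inhibition and lower numbers for stronger inhibition:
- Compound 1 `COc1ccc([C@@H]2[C@H](Oc3ccccc3)C(=O)N2c2cc(OC)c(OC)c(OC)c2)cc1OC`: 26000 nM
- Compound 2 `COc1cc(N2C(=O)[C@@H](Oc3ccccc3)[C@H]2c2ccc([N+](=O)[O-])cc2)cc(OC)c1OC`: 63000 nM
- Compound 3 `COc1cc(N2C(=O)[C@@H](Oc3ccccc3)[C@H]2c2ccc([S+](C)[O-])cc2)cc(OC)c1OC`: 20000 nM

These three compounds share a core and differ only in one aromatic group. Compound 3, at 20000 nM, cannot be told apart from compound 1, and it gives a clearly lower number than compound 2.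

The next structure is compound 4 `COc1ccc([C@@H]2[C@H](Oc3ccccc3)C(=O)N2c2cc(OC)c(OC)c(OC)c2)c([N+](=O)[O-])c1O`. It changes the same place, on a saturated ring carbon of a four-membered non-aromatic ring with 1 nitrogen, next to the ring nitrogen: a group of 12 heavy atoms (7 carbon, 1 nitrogen, 4 oxygen; one six-membered aromatic ring of carbon only) in place of a group of 9 heavy atoms (7 carbon, 1 oxygen, 1 sulfur; one six-membered aromatic ring of carbon only), on a saturated ring carbon.

Among the compounds with values here, three measured steps bear on this change, since each replaces a group at or within this same position. The first is a 1.3-fold lower number from compound 1 to compound 3 (0.11 log units; within the scatter). The second is a 2.4-fold higher number from compound 1 to compound 2 (0.38 log units; beyond the scatter), and the third is a 3.2-fold lower number from compound 2 to compound 3 (0.50 log units; beyond the scatter). All three are small or modest, so changes here have moved the number only a little so far. However, no measured compound carries the entering group, which leaves the prediction uncertain. In this assay, no step beyond the scatter is therefore expected, and no direction can be favoured.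

The expected outcome is a 1.1-fold higher number from compound 3 to compound 4 (0.04 log units; within the scatter). For compound 4, the estimated value is 22000 nM, with an expected range of 5000 nM to 70000 nM.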

Compound 4, half-maximal inhibitory concentration: 89000 nM
Compound 4: middle estimate off by 4.0-fold (0.61 log units), on the low side; the measured number lies above the stated range.
By their numbers in this assay, from the lowest: compounds 3 and 1 (each within the scatter of the next); then compounds 2 and 4 (each within the scatter of the next).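

In this assay, within the data shown here, this position allows a larger move than the earlier compounds showed: there is a 4.5-fold higher number from compound 3 to compound 4 (0.65 log units; beyond the scatter) and also a 3.4-fold higher number from compound 1 to compound 4 (0.53 log units; beyond the scatter), and both lie beyond the scatter. The picture is different against the 4-nitrophenyl group, with a 1.4-fold higher number from compound 2 to compound 4 (0.15 log units; within the scatter), so among these four compounds the two whose aryl groups carry a nitro group sit together at the higher numbers, apart from compounds 1 and 3. The aryl group can therefore shift the number by more than the first three compounds suggested, although nothing measured here accounts for this grouping.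

The compounds shown do not separate the hydroxy group on the aryl ring of compound 4 from its nitro group, so what each contributes alone stays open. From the compounds shown here alone, it is also open whether an aryl ring carrying an amine or a carboxylic acid would fall with compounds 1 and 3 or with compounds 2 and 4.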